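A Smaller Halogen Ring Replaces the Isopropyl Ring

The source may hold more compounds than are shown below. What is called first, only, known or untested is meant among the compounds shown, and "the series" means these compounds.

Of the compounds shown here, three sharing one core have been tested in a functional assay on PC-3 cells (Homo sapiens) for antiproliferative activity, read by MTT assay, with a stated time of 72 h; on this read-out higher numbers stand for weaker inhibition and lower numbers for stronger inhibition. Compound 1 `O=C(COc1ccc(C(=O)/C=C/c2ccccc2Br)cc1)N[C@H]1CCOC1=O` gives 3260 nM, compound 2 `CC(C)(C)c1ccc(/C=C/C(=O)c2ccc(OCC(=O)N[C@H]3CCOC3=O)cc2)cc1` gives 10600 nM, and compound 3 `CC(C)c1ccc(/C=C/C(=O)c2ccc(OCC(=O)N[C@H]3CCOC3=O)cc2)cc1` gives 4660 nM. Compound 3 thus stands second highest of the three, close to compound 1 and clearly below compound 2. Compound 4 `O=C(COc1ccc(C(=O)/C=C/c2cccc(Cl)c2)cc1)N[C@H]1CCOC1=O` carries 3-chlorophenyl in place of 4-isopropylphenyl on a double-bonded chain carbon bound to a double-bonded chain carbon. Within the data shown here, the steps that bear on this are a 1.4-fold higher number from compound 1 to compound 3 (0.16 log units; within the scatter) and a 2.3-fold lower number from compound 2 to compound 3 (0.36 log units; beyond the scatter): a smaller group on this ring went with a lower number, while the halogen-bearing ring of compound 1 sat within the scatter of compound 3. Compound 4 is therefore expected to show a small downward step or none beyond the scatter, a 1.5-fold lower number from compound 3 to compound 4 (0.16 log units; within the scatter). Compound 4 is estimated at 3200 nM, with a range from 1500 nM to 7000 nM.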

Compound 4, half-maximal inhibitory concentration: 4990 nM
For compound 4 the middle estimate is 1.6-fold (0.19 log units) below the measured one; measured number inside the range.
By their numbers in this assay, from the lowest: compounds 1, 3 and 4 (each within the scatter of the next); then compound 2.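

In this assay, 3-chlorophenyl on this double-bonded chain carbon cannot be told apart from 4-isopropylphenyl (a 1.1-fold higher number from compound 3 to compound 4 (0.03 log units; within the scatter)) or from 2-bromophenyl (a 1.5-fold higher number from compound 1 to compound 4 (0.18 log units; within the scatter)). This shows that a chlorine-bearing ring can take the place of the isopropyl-bearing ring with no step beyond the scatter, while 4-(tert-butyl)phenyl alone stands apart (a 2.1-fold lower number from compound 2 to compound 4 (0.33 log units; beyond the scatter)). Nothing measured here explains these results. Going by these compounds, it remains open whether a phenyl ring bearing an amine or a carboxylic acid at this place would give a number outside this range.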